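The source may report more compounds than this note shows. Statements on the series, on what has been measured and on what is new or still open speak of the compounds shown alone.

Measured compounds in an assay on isolated protein for binding affinity to leukotriene B4 receptor 1 (Homo sapiens), tested at 1 uM; a higher number here means more inhibition at the concentration tested (going by the name of the read-out), a lower number less inhibition:
compound 1, `C=CCc1cc(C(C)=O)c(O)cc1OCCCCCCCCC#N`, 50%
compound 2, `C=CCc1cc(C(C)=O)c(O)cc1OCCCCCCCCCCC#N`, 14%
compound 3, `C=CCc1cc(C(C)=O)c(O)cc1OCCCC`, 8%

Compound 3 has the lowest of the three numbers in this assay. Its nearest neighbour is compound 2, and the step of a number 6 percentage points lower from compound 2 to compound 3 (within the scatter) lies within the scatter, so the two cannot be ordered. Compound 1 stands well apart: the step of a number 42 percentage points lower from compound 1 to compound 3 (beyond the scatter) is large and beyond the scatter, as is the step of a number 36 percentage points lower from compound 1 to compound 2 (beyond the scatter).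

Compound 4, `C=CCc1cc(C(C)=O)c(O)cc1OCCCCCC`, is not yet measured. Relative to compound 3 the change is ethyl in place of hydrogen on a saturated chain carbon, four bonds along the chain from an oxygen on an aromatic ring. The two measured steps at this same place both put hydrogen in for a nitrile-bearing chain, and they disagree in size: the drop a number 42 percentage points lower from compound 1 to compound 3 (beyond the scatter) was large, while a number 6 percentage points lower from compound 2 to compound 3 (within the scatter) stayed within the scatter. Among the measured compounds shown here, no measured step covers a plain alkyl extension without a nitrile, so the only guide is that the shorter chain of compound 2 gave a value close to that of compound 3, and that the hydrogen-terminated chain of compound 3 sits at the bottom.

A step of a number 4 percentage points higher from compound 3 to compound 4 (within the scatter) is therefore expected, within the scatter or close to it, with little room downward. For compound 4 the estimate in this assay is 12%, in the range 2% to 30%.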

Compound 4, a percentage reported as inhibition, at one concentration (the size of the read-out at that concentration, not a potency): 9%
Compound 4: the middle estimate sits 3 percentage points above what was measured; low and high end bracket the measured number.
By their numbers in this assay, from the lowest: compounds 3, 4 and 2 (each within the scatter of the next); then compound 1.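

In this assay, ethyl in place of hydrogen on a saturated chain carbon, four bonds along the chain from an oxygen on an aromatic ring, gives a number 1 percentage points higher from compound 3 to compound 4 (within the scatter), so this plain alkyl extension has no readable effect in this pair. Among the compounds shown here, compound 4 also gives the first comparison of a plain chain with the nitrile-bearing chains: hydrogen in place of 2-cyanoethyl gives a number 41 percentage points lower from compound 1 to compound 4 (beyond the scatter), while hydrogen in place of 4-cyanobutyl gives a number 5 percentage points lower from compound 2 to compound 4 (within the scatter), so only the chain of compound 1 stands clear of the plain chain. Hydrogen in place of 4-cyanobutyl has no single size in this series and depends on the chain that carries it: the same change on two cores in this assay, a number 42 percentage points lower (beyond the scatter) from compound 1 to compound 3 and a number 5 percentage points lower (within the scatter) from compound 2 to compound 4, 37 percentage points apart, beyond the scatter of two such steps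

Still open, going by these compounds, is whether the value of compound 1 needs the nitrile at all, since a longer plain alkyl chain matching its length would be needed to separate chain length from the end group. Also open, on these data alone, is how a shorter nitrile-bearing chain, or a carboxylic acid or an amine at the chain end, would read in this assay.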